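Small Aryl Swap in a Series Without Growth Inhibition

A few compounds are considered here, and "the series" means these few. Any claim that something is new, unique, unknown or untested is made for them only; others in the source may bear on it.

Compound 1 `CN(C)C(=O)c1cc2cnc(Nc3ccc(NC(=O)C4(C(=O)Nc5ccc(F)cc5)CC4)cc3F)nc2n1C1CCCC1`: -0.9%
Compound 2 `CN(C)C(=O)c1cc2cnc(Nc3ccc(NC(=O)C4(C(=O)Nc5ccc(Cl)c(C(F)(F)F)c5)CC4)cc3)nc2n1C1CCCC1`: -2.4%

Of the compounds shown here, two have been tested in a functional assay on OVCAR-5 cells (Homo sapiens) for inhibition, read by CCK-8 assay, with a stated time of 72 h, tested at 1 uM; on this read-out higher numbers stand for more inhibition of growth at the one concentration tested and lower numbers for less inhibition of growth. Compound 1 gives -0.9%. Compound 2 gives -2.4%. Among the measured compounds shown here, on these two numbers compound 2 stands at the lower end, but its only neighbour, compound 1, sits within the scatter of it, so neither can be called weaker or stronger; both show essentially no growth inhibition at the concentration tested.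

Compound 3 `CN(C)C(=O)c1cc2cnc(Nc3ccc(NC(=O)C4(C(=O)Nc5ccc(F)cc5)CC4)cc3)nc2n1C1CCCC1` has not yet been measured. It differs from compound 2 in one place: 4-fluorophenyl in place of 4-chloro-3-(trifluoromethyl)phenyl on an amide-type nitrogen. For the measured compounds named here, no step between measured compounds is available to guide the expectation. Since compound 2 already sits at -2.4%, the step in this assay from compound 2 to compound 3 is expected to be none beyond the scatter. Compound 3 is therefore estimated at 0%, within a range from -10% to 12%, an expected change of a number 2.4 percentage points higher from compound 2 to compound 3 (within the scatter).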

Compound 3, percent growth inhibition at one concentration: 65.4%
Estimate against measurement, compound 3: 65.4 percentage points below, outside the stated range (above it).
By their numbers in this assay, from the lowest: compounds 2 and 1 (each within the scatter of the next); then compound 3.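

In this assay, the group on the amide-type nitrogen proves to matter a great deal: 4-fluorophenyl in place of 4-chloro-3-(trifluoromethyl)phenyl gives a number 67.8 percentage points higher from compound 2 to compound 3 (beyond the scatter) while everything else stays the same. A single atom on the other side of the molecule matters as much, since hydrogen in place of fluoro on an aromatic carbon gives a number 66.3 percentage points higher from compound 1 to compound 3 (beyond the scatter) in the same read-out, so the two earlier compounds, alike in their numbers, hid two separate places where growth inhibition is lost. Nothing measured here explains either step.

Still open, going by these compounds, is whether the chlorine or the trifluoromethyl accounts for the loss in compound 2, which a 4-chlorophenyl or a 3-(trifluoromethyl)phenyl on the amide-type nitrogen would help to separate. Also open, on these data alone, is how a chloro or a methoxy on that aromatic carbon would compare with the hydrogen of compound 3.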